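Solubility Outlook for a Hydroxylated Bicyclic Amide Analogue

The source may report more compounds than this note shows. Statements on the series, on what has been measured and on what is new or still open speak of the compounds shown alone.

Compound 1, `CNC(=O)c1cc(C(=O)N[C@H]2CC[C@H](O)CC2)cc2c1OC[C@@]2(C)c1ccccc1`, in a physicochemical assay for solubility (on this read-out lower numbers stand for lower solubility and higher numbers for higher solubility), gives >= 161 ug/mL, which is a limit of the assay and not a number.
Compound 2, `CNC(=O)c1cc(C(=O)Nc2cnn(C)c2)cc2c1OC[C@H]2c1ccccc1`, in this assay gives >= 189 ug/mL, again a limit rather than a number.
Compound 3, `CNC(=O)c1cc(C(=O)N[C@H]2[C@@H]3COC[C@@H]32)cc2c1OC[C@H]2C1CCOCC1`, in this assay gives >= 177 ug/mL, also a limit.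

Every value shown so far is therefore a limit: compound 2 sits at one (the limit of >= 189 ug/mL in this assay, at which 1 of the 3 values shown sits), and the other two compounds sit at their own limits (the limit of >= 161 ug/mL in this assay, at which 1 of the 3 values shown sits, (the limit of >= 177 ug/mL in this assay, at which 1 of the 3 values shown sits)). Going by the values given here, no step between measured compounds that differ in one place is available, so nothing measured tells how large a single change moves the read-out.

Compound 4, `CNC(=O)c1cc(C(=O)N[C@H]2[C@@H]3C[C@@H](O)C[C@@H]32)cc2c1OC[C@H]2c1ccccc1`, differs from compound 2 in one place: a group of 7 heavy atoms (6 carbon, 1 oxygen; one three-membered non-aromatic ring of carbon only, one five-membered non-aromatic ring of carbon only) in place of a group of 6 heavy atoms (4 carbon, 2 nitrogen; one five-membered aromatic ring with 2 hetero atoms), on an amide-type nitrogen. Compound 1 carries a hydroxylated saturated ring on the same amide-type nitrogen and reaches a limit, so the hydroxyl-bearing group entering in compound 4 gives no ground to expect a fall below the scatter. The expected step from compound 2 to compound 4 is none beyond the scatter, an at least 1.0-fold lower number from compound 2 to compound 4 (0.02 log units; that floor lies within the scatter). Compound 4 is accordingly expected to give 180 ug/mL, within 70 ug/mL to 300 ug/mL, most likely reported again as a limit.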

Compound 4, solubility: >= 124 ug/mL
Compound 4: only a limit was reported; the forecaster's own chance of this, stated with the estimate: 65%; the middle value does not contradict the limit.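

Compound 2 and compound 4 both give limits in this assay, not numbers, and the step from one to the other cannot be read. The compounds shown leave open where the true value of each lies and how far a change in one place moves the read-out.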